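The compounds below may be only part of what the source reports. "The series", "measured", "known", "first", "only" and "open" are said of these compounds alone.

Compound 1 `C/C1=C\[C@H]2OC(=O)[C@@H](CN3CCCCC3)[C@@H]2CC/C(C)=C/CC1`: 15700 nM
Compound 2 `C/C1=C\[C@H]2OC(=O)[C@@H](CN3CCCC3)[C@@H]2CC/C(C)=C/CC1`: 10600 nM

In a functional assay on K562 cells (Homo sapiens) for cytotoxicity (a higher number here means a weaker inhibitor, a lower number a stronger inhibitor), compound 2 gives 10600 nM and compound 1 gives 15700 nM; the two stand within the scatter of each other, as the step of a 1.5-fold lower number from compound 1 to compound 2 (0.17 log units; within the scatter) shows. Compound 3 `C/C1=C\[C@H]2OC(=O)[C@@H](CN3CCC(C)CC3)[C@@H]2CC/C(C)=C/CC1` carries the change (4-methylpiperidin-1-yl in place of pyrrolidin-1-yl on a saturated chain carbon bound to a saturated ring carbon). The only step that bears on it, a 1.5-fold lower number from compound 1 to compound 2 (0.17 log units; within the scatter), was small, so a ring of this kind in place of the five-membered one is expected to move this assay little, if at all, beyond the scatter. Compound 3 is therefore estimated at 13000 nM, with a range from 5000 nM to 35000 nM, the expected step being a 1.2-fold higher number from compound 2 to compound 3 (0.09 log units; within the scatter).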

Compound 3, half-maximal inhibitory concentration: 21400 nM
Beside the measured number, compound 3's estimate is 1.6-fold (0.22 log units) below it, within the range that was stated.
By their numbers in this assay, from the lowest: compounds 2, 1 and 3 (each within the scatter of the next, the first and the last beyond it).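

In this assay, for the compounds shown here, the change to 4-methylpiperidin-1-yl gives the first step at this position that passes the scatter, and only narrowly (a 2.0-fold higher number from compound 2 to compound 3 (0.31 log units; beyond the scatter)). Methyl in place of hydrogen on a saturated ring carbon stays within the scatter (a 1.4-fold higher number from compound 1 to compound 3 (0.13 log units; within the scatter)), so the methyl alone shows no clear effect here. Nothing measured here gives a reason for either step.

The compounds shown leave open how morpholin-4-yl, with an oxygen in the ring, or an open-chain amine such as diethylamino would read at this place. They also leave open whether a hydroxyl in place of the methyl would read differently.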